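Thiophene Replacing a Fluorophenyl Sulfonyl Group

This account rests on a few compounds, and the source may have more. Where it says the series, first, only, none or still open, it means among the compounds named here.

Measured compounds:
compound 1 `CNCc1cc(-c2ccccc2F)n(S(=O)(=O)c2ccc(C)cc2)c1` with 91%
compound 2 `CNCc1cc(-c2cccnc2F)n(S(=O)(=O)c2cccc(F)c2)c1` with 99%

Of the compounds shown here, two have been measured in a functional assay on the whole organism (strain Jcl:SD) for inhibition, with Rattus norvegicus as the target, with stated times of 3 min and 3 h, at a dose of 1 mg/kg by the intravenous route; on this read-out higher numbers stand for more inhibition at the one dose given (going by the name of the read-out) and lower numbers for less inhibition. Compound 2 gives 99%, the higher of the two numbers, while compound 1 gives 91%; the gap between them is within the usual scatter of such measurements, so the two compounds cannot be told apart on this read-out. Both numbers sit near the top of what a percentage inhibition can show, leaving little room for any compound to appear stronger.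

Compound 3 `CNCc1cc(-c2cccnc2F)n(S(=O)(=O)c2ccsc2)c1` is the compound that has not yet been measured. It differs from compound 2 in one place: thiophen-3-yl in place of 3-fluorophenyl on a sulfonyl sulfur. Among the measured compounds shown here, no step between two measured compounds touches this part of the molecule, so there is no direct guide to what the exchange does. Given that compound 2 gives 99% and compound 1 gives 91% at the same dose, the numbers of both measured compounds are high, and the expected step from compound 2 to compound 3 is a number 9 percentage points lower from compound 2 to compound 3 (within the scatter), a small loss that may well stay within the scatter. Compound 3 is therefore estimated to give 90% in this assay, with a range from 70% to 100%.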

Compound 3, a percentage reported as inhibition, in the whole organism at one dose (the size of the read-out at that dose, not a potency): 98%
Beside the measured number, compound 3's estimate is 8 percentage points below it, and the stated range covers the measured number.
By their numbers in this assay, from the lowest: compounds 1, 3 and 2 (each within the scatter of the next).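

In this assay, putting thiophen-3-yl in place of 3-fluorophenyl on a sulfonyl sulfur gives a number 1 percentage points lower from compound 2 to compound 3 (within the scatter), so compound 2 and compound 3 cannot be told apart on this read-out. Among the compounds shown here, this is the first direct look at this position: at this dose, the read-out stays high when a six-membered aromatic ring of carbon only, bearing fluorine, gives way to a five-membered aromatic ring with 1 hetero atom, and the group goes from 7 heavy atoms to 5. Nothing shown explains why the exchange leaves the number so high.

Going by these compounds, both compounds sit close to the top of a percentage scale at a single dose, so a real difference in potency between compound 2 and compound 3 could stay hidden, and the size of any such difference remains open. Also open is whether the sulfonyl sulfur needs an aromatic ring at all, since the compounds shown do not include a saturated ring such as cyclohexyl or a small alkyl group such as methyl at this place.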